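The compounds below may be only part of what the source reports. "The series", "measured", "known", "first", "only" and "open" are said of these compounds alone.

Of the compounds shown here, three sharing one core have been measured in an ADME assay for permeability, using PAMPA, in phosphate buffer, with a stated time of 18 h, at pH 7.4 (on this read-out higher numbers stand for higher permeability and lower numbers for lower permeability), so far. Compound 1 `Nc1ccc2oc(N3CCN(c4ccc(Cl)cc4)CC3)nc2c1` gives 10.6 10^-6 cm/s and compound 2 `Nc1ccc2oc(N3CCN(c4ccc(F)cc4)CC3)nc2c1` gives 10.7 10^-6 cm/s there, while compound 3 `Cc1ccc(N2CCN(c3nc4cc(N)ccc4o3)CC2)cc1` gives 10.4 10^-6 cm/s and so stands level with both within the scatter. Compound 4 `COc1ccc(N2CCN(c3nc4cc(N)ccc4o3)CC2)cc1` is still unmeasured and differs from compound 3 by one change, methoxy in place of methyl on an aromatic carbon (methoxy in place of methyl on an aromatic carbon, para to a large group). The measured steps that bear on it also swap a group on an aromatic carbon: a 1.0-fold higher number from compound 1 to compound 2 (0.00 log units; within the scatter) for fluoro in place of chloro, a 1.0-fold lower number from compound 1 to compound 3 (0.01 log units; within the scatter) for methyl in place of chloro, and a 1.0-fold lower number from compound 2 to compound 3 (0.01 log units; within the scatter) for methyl in place of fluoro. All three lie within the scatter, but none involves methoxy, so the data do not test that group directly. Starting from compound 3 at 10.4 10^-6 cm/s and given those steps, no step beyond the scatter is expected in this assay for this change. The estimated step is a 1.0-fold lower number from compound 3 to compound 4 (0.02 log units; within the scatter) and so stays within the scatter. For compound 4 the estimated value is 10 10^-6 cm/s with the expected range running from 7 10^-6 cm/s to 12.5 10^-6 cm/s at its two ends.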

Compound 4, apparent permeability: 10.5 10^-6 cm/s
For compound 4 the middle estimate is 1.1-fold (0.02 log units) below the measured one; the range from low to high includes it.
By their numbers in this assay, from the lowest: compounds 3, 4, 1 and 2 (each within the scatter of the next).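

Methoxy, set in place of methyl on an aromatic carbon para to a large group, leaves the number in this assay within the scatter (a 1.0-fold higher number from compound 3 to compound 4 (0.00 log units; within the scatter)). Methoxy carries an oxygen and a hydrogen-bond acceptor that methyl lacks, yet the comparisons with the two halogen compounds also stay within the scatter (a 1.0-fold lower number from compound 2 to compound 4 (0.01 log units; within the scatter); a 1.0-fold lower number from compound 1 to compound 4 (0.00 log units; within the scatter)), so all four groups now read alike at this position. Nothing available explains this flat result.

As far as these compounds go, all four compounds vary this one position on the shared core, so whether changes elsewhere would also leave the number flat stays open. Also open, from the compounds shown here alone, is whether an amine, a carboxylic acid or a longer chain at this position would break the pattern.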